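This account rests on a few compounds, and the source may have more. Where it says the series, first, only, none or still open, it means among the compounds named here.

Measured so far in an assay on brain for displacement of a labelled ligand from D(3) dopamine receptor (Rattus norvegicus); on this read-out lower numbers stand for stronger inhibition and higher numbers for weaker inhibition:
compound 1 `CCCN(CC[C@H]1CC[C@H](NC(=O)/C=C/c2cccc(Cl)c2)CC1)[C@H]1CCc2nc(N)sc2C1`; in this assay compound 1 gives 1.2 nM
compound 2 `CCCN(CC[C@H]1CC[C@H](NC(=O)c2ccc(-n3ccnc3)cc2)CC1)[C@H]1CCc2nc(N)sc2C1`; in this assay compound 2 gives 1.9 nM

Among the compounds with values here, compound 1 holds the lowest of the two numbers, but the only step among the measured compounds, a 1.6-fold higher number from compound 1 to compound 2 (0.20 log units; within the scatter), lies within the scatter, so compound 1 and compound 2 are not separated in this assay.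

The unmeasured compound 3 `CCCN(CC[C@H]1CC[C@H](NS(=O)(=O)c2ccccc2Cl)CC1)[C@H]1CCc2nc(N)sc2C1` differs from compound 1 at the amine nitrogen: (2-chlorophenyl)sulfonyl in place of (2-(3-chlorophenyl)ethenyl)carbonyl on an amine nitrogen. Within the data shown here, the one measured step exchanges the group on the carbonyl carbon while the carbonyl itself remains, and that step was small. Among the measured compounds shown here, the step to compound 3 removes the carbonyl and brings in a sulfonyl; no measured pair alters this part of the molecule in that way, so the measured step bears on it only loosely. A modest rise in the number is expected, weaker binding rather than stronger, though with wide uncertainty.

For compound 3 the estimate in this assay is 10 nM, with a range from 1.5 nM to 60 nM. The expected step is an 8.3-fold higher number from compound 1 to compound 3 (0.92 log units; beyond the scatter).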

Compound 3, inhibition constant: 0.68 nM
Compound 3: middle estimate off by 15-fold (1.17 log units), on the high side; measured number outside the range, below it.
By their numbers in this assay, from the lowest: compounds 3, 1 and 2 (each within the scatter of the next, the first and the last beyond it).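

In this assay, (2-chlorophenyl)sulfonyl in place of (2-(3-chlorophenyl)ethenyl)carbonyl on the amine nitrogen gives a 1.8-fold lower number from compound 1 to compound 3 (0.25 log units; within the scatter) and so leaves the two compounds unseparated. The earlier step changed only the group on a carbonyl carbon, whereas this one shows that the amine nitrogen can carry a sulfonyl instead of a carbonyl with no separation from compound 1. The exchange also removes the ethenyl link and pairs a 2-chlorophenyl with what was a 3-chlorophenyl, yet the combined change stays within the scatter, and no measurement at hand accounts for this result.

Open, going by these compounds, is how each part of this combined change acts alone, as a single step cannot divide the outcome among the sulfonyl, the missing ethenyl link and the chlorine placement. Also open, on these data alone, is how far the position extends beyond aryl groups, for instance to a methylsulfonyl group, or to a urea in place of the amide or sulfonamide link.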